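A benzothiazole amide in place of the trifluoromethylphenyl amide

The source may hold more compounds than are shown below. What is called first, only, known or untested is meant among the compounds shown, and "the series" means these compounds.

Of the compounds shown here, three that share one core have been measured in an assay on isolated protein for inhibition of histone deacetylase 8 (Homo sapiens), with a stated time of 1 h; on this read-out higher numbers stand for weaker inhibition and lower numbers for stronger inhibition. Compound 1 `O=C(COc1ccc2cc(/C=C3/SC(=O)NC3=O)ccc2c1)Nc1ccc(F)cc1F` sits at a limit of the assay, with > 50000 nM. Compound 2 `O=C(COc1ccc2cc(/C=C3/SC(=O)NC3=O)ccc2c1)Nc1ccccc1` gives a number, 4500 nM. Compound 3 `O=C(COc1ccc2cc(/C=C3/SC(=O)NC3=O)ccc2c1)Nc1cccc(C(F)(F)F)c1` likewise sits at a limit, with > 50000 nM. Among the compounds with values here, the one readable step runs an at least 11-fold lower number from compound 1 to compound 2 (1.04 log units; beyond the scatter); the step of an at least 11-fold higher number from compound 2 to compound 3 (1.04 log units; beyond the scatter) ends at the limit, and a step that the two limits leave unreadable from compound 1 to compound 3 runs between two limits. Two of the three values thus rest at the limit of > 50000 nM in this assay, at which 2 of the 3 values shown sit. Compound 4 `Cc1cccc2sc(NC(=O)COc3ccc4cc(/C=C5/SC(=O)NC5=O)ccc4c3)nc12` is still to be measured; it differs from compound 3 in one place: 4-methyl-1,3-benzothiazol-2-yl in place of 3-(trifluoromethyl)phenyl on an amide-type nitrogen. Within the data shown here, no measured step tests a change of this kind on the amide-type nitrogen; the steps that touch that position show only that the plain phenyl of compound 2 gave a number, while compound 3 stands on a limit. The expectation is therefore wide: the number for compound 4 is estimated at 20000 nM, between 3000 nM and 50000 nM. This amounts to an expected step of an at least 2.5-fold lower number from compound 3 to compound 4 (0.39 log units; beyond the scatter).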

Compound 4, half-maximal inhibitory concentration: 5800 nM
For compound 4 the middle estimate is 3.4-fold (0.54 log units) above the measured one; the measured number falls inside the stated range.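

On the amide-type nitrogen, the two-ring 4-methyl-1,3-benzothiazol-2-yl group restores a measurable number in this assay where two substituted phenyl groups gave none: replacing 3-(trifluoromethyl)phenyl gives an at least 8.6-fold lower number from compound 3 to compound 4 (0.93 log units; beyond the scatter), and replacing 2,4-difluorophenyl gives an at least 8.6-fold lower number from compound 1 to compound 4 (0.93 log units; beyond the scatter). Replacing the plain phenyl gives a 1.3-fold higher number from compound 2 to compound 4 (0.11 log units; within the scatter), so this position accepts the benzothiazole group and the plain phenyl alike on this read-out. The starting values of compound 1 and compound 3 are limits of the assay, not numbers, so the full size of those two steps stays unknown: the limit of > 50000 nM in this assay, at which 2 of the 4 values shown sit.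

The compounds shown leave open what the 4-methyl group contributes to the number of compound 4. They also leave open how a 1,3-benzothiazol-2-yl group without the methyl, or a phenyl carrying a methyl or an amine, would read.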